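The source may hold more compounds than are shown below. What is called first, only, known or untested is meant among the compounds shown, and "the series" means these compounds.

Measured compounds:
Compound 1 `CCCOC(=O)C1=C(C)N(C)C(=O)NC1c1ccco1` gives 8% in an assay on membranes from HeLa cells for displacement of a labelled ligand from adenosine receptor A3 (Homo sapiens), read by scintillation counting, with a stated time of 180 min, tested at 1 uM; a lower number here means less inhibition, a higher number more inhibition at the concentration tested (going by the name of the read-out).
Compound 2 `CC1=C(C(=O)OC(C)(C)C)C(c2ccco2)NC(=O)N1C` gives 54% in this assay.

Among the compounds with values here, compound 2 stands highest of the two numbers; its nearest neighbour is compound 1, and the only measured step, a number 46 percentage points higher from compound 1 to compound 2 (beyond the scatter), is the large gain seen with tert-butyl in place of propyl on an oxygen next to a carbonyl group. Compound 3 `CC1=C(C(=O)OC(C)(C)C)C(c2ccsc2)NC(=O)N1C` keeps the tert-butoxycarbonyl group of compound 2 and differs from it only by thiophen-3-yl in place of furan-2-yl on a saturated ring carbon. No measured step bears on this exchange: the one step shown concerns the ester, not the group on the saturated ring carbon. Compound 3 is therefore expected to stay close to compound 2 in this assay, with an estimated step of a number 4 percentage points lower from compound 2 to compound 3 (within the scatter), not beyond the scatter, and an estimate for compound 3 of 50%, with a range from 25% to 75%.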

Compound 3, a percentage reported as inhibition, at one concentration (the size of the read-out at that concentration, not a potency): 14%
For compound 3 the middle estimate is 36 percentage points above the measured one; measured number below the stated range.
By their numbers in this assay, from the lowest: compounds 1 and 3 (each within the scatter of the next); then compound 2.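

In this assay, the group on the saturated ring carbon matters as well as the ester: with the tert-butoxycarbonyl group kept, thiophen-3-yl in place of furan-2-yl gives a number 40 percentage points lower from compound 2 to compound 3 (beyond the scatter), a large step. The tert-butoxycarbonyl group alone therefore does not secure the higher number, and the result depends on which ring sits at this position, even though both groups are five-membered aromatic rings with 1 hetero atom and match in heavy atoms, donors and acceptors. Nothing available here accounts for this difference.

The exchange changes both the hetero atom and the point of attachment, and the compounds shown cannot separate the two, which thiophen-2-yl or furan-3-yl could do. Also open, as far as these compounds go, is how a phenyl group at this position would compare, and whether the same exchange would matter with the propyl ester.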